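This account rests on a few compounds, and the source may have more. Where it says the series, first, only, none or still open, it means among the compounds named here.

Working notes on the series. The shared core is that of compound 1 `C/C=C1/[C@H](O[C@@H]2O[C@H](CO)[C@@H](O)[C@H](O)[C@H]2O)OC=C(C(=O)OC)[C@H]1CC(=O)OCCc1ccc(O)c(O)c1`, a glycoside carrying a methyl ester and a longer side-chain ester. Among the compounds with values here, in a functional assay on SK-BR-3 cells (Homo sapiens) for antiproliferative activity, read by MTT assay, with a stated time of 72 h (a higher number here means a weaker inhibitor, a lower number a stronger inhibitor), compound 1 gives 160000 nM, the only numerical reading among the three measured members. Compound 2 `C/C=C1/[C@H](O[C@@H]2O[C@H](COC(C)=O)[C@@H](OC(C)=O)[C@H](OC(C)=O)[C@H]2OC(C)=O)OC=C(C(=O)OC)[C@H]1CC(=O)OCC` carries acetyl groups on the sugar and an ethyl ester; for compound 2 this assay reports only the limit > 15000 nM. Compound 3 `C/C=C1/[C@H](O[C@@H]2O[C@H](CO)[C@@H](O)[C@H](O)[C@H]2O)OC=C(C(=O)OC)[C@H]1CC(=O)OCCCC` has a butyl ester where compound 1 has its side chain; for compound 3 this assay again reports only the limit > 15000 nM. The one-place change a step that the limit leaves unreadable from compound 1 to compound 3 therefore cannot be sized, because the limit of > 15000 nM in this assay, at which 2 of the 3 values shown sit, covers two of the three values. Compound 4 `C/C=C1/[C@H](O[C@@H]2O[C@H](CO)[C@@H](O)[C@H](O)[C@H]2O)OC=C(C(=O)OC)[C@H]1CC(=O)OCCc1ccccc1` differs from compound 1 at a single place: phenyl in place of 3,4-dihydroxyphenyl on a saturated chain carbon, two bonds along the chain from an oxygen next to a carbonyl group. Within the data shown here, the only measured step touching the same side chain, that from compound 1 to compound 3, is unreadable, so no measured step gives a size or direction for this change. The expectation for compound 4 rests on compound 1 alone, with the step of a 1.1-fold higher number from compound 1 to compound 4 (0.05 log units; within the scatter) expected to stay within the usual scatter. Compound 4 is accordingly estimated at 180000 nM, with an expected range from 60000 nM to 500000 nM.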

Compound 4, half-maximal inhibitory concentration: 11000 nM
Estimate against measurement, compound 4: 16-fold (1.21 log units) above, outside the stated range (below it).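

In this assay, the change on this saturated chain carbon, two bonds along the chain from an oxygen next to a carbonyl group, now has a size and a direction: phenyl in place of 3,4-dihydroxyphenyl gives a 15-fold lower number from compound 1 to compound 4 (1.16 log units; beyond the scatter). Both groups hold the same six-membered aromatic ring of carbon only, so this step goes with what 3,4-dihydroxyphenyl carries on that ring and not with the ring itself. Phenyl in place of ethyl reads only as an at least 1.3-fold lower number from compound 3 to compound 4 (0.13 log units; that floor lies within the scatter), a floor within the scatter from which no order of the two follows, and the true size stays hidden behind the limit of the assay: the limit of > 15000 nM in this assay, at which 2 of the 4 values shown sit.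

Still open, as far as these compounds go, is whether a single hydroxyl on the phenyl, or methoxy groups in place of the hydroxyls of 3,4-dihydroxyphenyl, would read closer to compound 1 or to compound 4. Also open, from the compounds shown here alone, is whether a longer chain carrying the phenyl, or a pyridine ring in place of the phenyl, would move the number further in the same direction.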